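Trading a chloro for a methyl

The source may hold more compounds than are shown below. What is called first, only, known or untested is meant among the compounds shown, and "the series" means these compounds.

Compound 1 (`CC(C)(C)NCc1cc(Cl)cc(Nc2nc3ccccc3n2Cc2ccc(C(F)(F)F)cc2)c1O`) is a useful starting point for a small structural swap. For the measured compounds named here, in an ADME assay on microsomes from liver (Mus musculus) for metabolic stability, read by LC-MS, with a stated time of 30 min, tested at 1 uM (a higher number here means that more of the compound is left, a lower number that less of the compound is left), compound 1 gives 36% and is the lower of the two compounds measured so far. Compound 2 (`CCNCc1cc(Cl)cc(Nc2nc3cc(F)c(F)cc3[nH]2)c1O`) gives 98% in this assay and stands well above it, beyond the usual scatter. Going by the values given here, no two measured compounds differ in only one place, so the data offer no direct guide to any single swap.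

Compound 3 (`Cc1cc(CNC(C)(C)C)c(O)c(Nc2nc3ccccc3n2Cc2ccc(C(F)(F)F)cc2)c1`) keeps almost all of compound 1, with one change: methyl in place of chloro on an aromatic carbon. This is methyl in place of chloro on an aromatic carbon, para to a hydroxy group. Among the compounds with values here, since only this one group changes, the expectation stays anchored on compound 1 at 36% and not on compound 2. A slight downward move is expected, estimated as a number 7 percentage points lower from compound 1 to compound 3 (within the scatter) and likely to stay within the scatter. The estimate for compound 3 is 29% with an expected range from 12% to 50% across repeat measurements.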

Compound 3, percent of the compound remaining: 62%
Beside the measured number, compound 3's estimate is 33 percentage points below it; the measured number lies above the stated range.
By their numbers in this assay, from the lowest: compound 1; then compound 3; then compound 2.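

Putting methyl in place of chloro on this aromatic carbon, para to a hydroxy group, gives a number 26 percentage points higher from compound 1 to compound 3 (beyond the scatter) in this assay and counts as a modest step. For the compounds shown here, compounds 1 and 3 form the first pair here that differs in one place, so this step shows that a change at this single position can by itself shift how much compound is left, while the ((tert-butyl)amino)methyl group and the rest of the core of compound 1 stay the same. No measurement at hand explains why the percentage remaining rises with this swap, so the step describes what happens and gives no reason for it.

One swap cannot show how other groups would behave at this position: a methoxy group, a bromine or an amine might sit close to compound 1, close to compound 3, or far from both. On these data alone, it also remains open whether methyl in place of chloro would give a step of similar size and direction on a different core, such as that of compound 2.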